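Sulfonamide series: the step from compound 1 to compound 4

This account rests on a few compounds, and the source may have more. Where it says the series, first, only, none or still open, it means among the compounds named here.

Measured so far in a physicochemical assay for lipophilicity, at pH 7.4; on this read-out higher numbers stand for higher lipophilicity and lower numbers for lower lipophilicity:
- compound 1 `CC(C)CN(C1CCc2ccc(F)cc21)S(=O)(=O)c1ccc2c(c1)C(=O)CC(C1CCOCC1)O2`: 4.03
- compound 2 `CCc1ccc(N(CC(C)C)S(=O)(=O)c2ccc(OCC3CCOCC3)c3c2CCCC3=O)cc1`: 4.84
- compound 3 `CCc1ccc(N(CC2CC2)S(=O)(=O)c2ccc3c(c2)C(=O)CC(C2CCOCC2)O3)cc1`: 3.77

Compound 1 stands within the usual scatter of compound 3, while compound 2 lies higher, beyond that scatter. Compound 4 `CC(C)CN(c1cccc(F)c1)S(=O)(=O)c1ccc2c(c1)C(=O)CC(C1CCOCC1)O2` carries 3-fluorophenyl in place of 6-fluoro-2,3-dihydro-1H-inden-1-yl on a sulfonamide nitrogen. Going by the values given here, no measured pair isolates a change of this kind, so the expectation rests on the three values alone. A modest fall in this assay is expected, an estimated a number 0.33 log units lower from compound 1 to compound 4 (beyond the scatter). The starting point is compound 1 at 4.03, and the expectation stays close to compound 3 at 3.77. The expected value for compound 4 is 3.7, with an estimated range of 3.3 to 4.1.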

Compound 4, distribution coefficient: 3.5
Compound 4: middle estimate off by 0.20 log units, on the high side; measured number inside the range.
By their numbers in this assay, from the lowest: compounds 4, 3 and 1 (each within the scatter of the next, the first and the last beyond it); then compound 2.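

Going by these compounds alone, on a sulfonamide nitrogen, 3-fluorophenyl in place of 6-fluoro-2,3-dihydro-1H-inden-1-yl forms the only pair here that differs in one place. In this assay this change gives a number 0.53 log units lower from compound 1 to compound 4 (beyond the scatter) and shows that this position can move the read-out beyond the scatter. The change removes the five-membered non-aromatic ring and goes from 10 heavy atoms to 7, but no available evidence bears on the origin of the step.

Within the data shown here, with only this pair, the ring and the size of the group cannot be separated. As far as these compounds go, how a pyridine ring or a carboxylic acid on this nitrogen would read in this assay remains open.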